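The source may report more compounds than this note shows. Statements on the series, on what has been measured and on what is new or still open speak of the compounds shown alone.

Notes on the series: in an ADME assay on microsomes from liver (Homo sapiens) for metabolic stability, read by LC-MS, using NADPH, with a stated time of 10 min, tested at 0.5 uM (on this read-out lower numbers stand for a less stable compound and higher numbers for a more stable compound), compound 1 (`CC(=O)Nc1cc(-c2ccc(OC[C@@H](N)CC(C)C)c(F)c2)ccn1`) gives 90% and compound 2 (`CC(=O)Nc1cc(-c2ccc(OC[C@@H](N)CC(C)C)c(Cl)c2)ccn1`) gives 89%. Among the measured compounds shown here, these are the only two measurements so far, and they lie within the scatter of each other. Compound 3 (`CC(=O)Nc1cc(-c2cc(F)c(OC[C@@H](N)CC(C)C)cc2F)ccn1`) has not yet been measured. It differs from compound 1 by one change: fluoro in place of hydrogen on an aromatic carbon. For the measured compounds named here, the one measured step that bears on this is a number 1 percentage points lower from compound 1 to compound 2 (within the scatter), for chloro in place of fluoro on an aromatic carbon. Going by the values given here, that is a different substitution, and no step for fluoro in place of hydrogen has been measured, so it is only a loose guide. No step beyond the scatter is expected in this assay. The estimated step is a number 3 percentage points lower from compound 1 to compound 3 (within the scatter). For compound 3 the expected value is 87%, with an estimated range of 70% to 97%.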

Compound 3, percent of the compound remaining: 78%
Estimate against measurement, compound 3: 9 percentage points above; the measured number falls inside the stated range.
By their numbers in this assay, from the lowest: compound 3; then compounds 2 and 1 (each within the scatter of the next).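

In this assay, among the compounds shown here, the step of a number 12 percentage points lower from compound 1 to compound 3 (beyond the scatter) is the first beyond the scatter, for fluoro in place of hydrogen on an aromatic carbon ortho to a large group, meta to a (2-amino-4-methylpentyl)oxy group and para to a fluoro group. For the compounds shown here, the earlier step of a number 1 percentage points lower from compound 1 to compound 2 (within the scatter) concerned only chloro in place of fluoro, so this is the first sign that the read-out responds to a substitution on this ring, and it rests on a single pair. No measurement at hand bears on what lies behind this step.

On these data alone, whether chloro, methyl or methoxy at the same position gives a step of similar size stays open. So does whether a hydroxyl in place of the amine of the side chain alters the number in compound 3.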